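This account rests on a few compounds, and the source may have more. Where it says the series, first, only, none or still open, it means among the compounds named here.

Three compounds share one core and differ in the groups hanging from it. Compound 1 `Cc1cc(C)cc(NC(=O)COc2cc(C)nc3ccc(C(F)(F)F)cc23)c1` was tested in a toxicity assay on HepG2 cells (Homo sapiens) for inhibition, read by CellTiter-Glo, with a stated time of 48 h (on this read-out lower numbers stand for stronger inhibition and higher numbers for weaker inhibition), and for compound 1 the result is a limit rather than a number, > 100000 nM. Compound 2 `CCOc1ccc2nc(C(F)(F)F)cc(OCC(=O)Nc3cc(C)cc(C)c3)c2c1` likewise gives only a limit in this assay, > 100000 nM. Compound 3 `COc1ccc2nc(C)cc(OCC(=O)Nc3cc(C)ccc3C)c2c1` stands at the same place: in this assay compound 3 gives a limit, > 100000 nM. Every value shown so far therefore sits at one and the same boundary, (the limit of > 100000 nM in this assay, at which 3 of the 3 values shown sit), so no difference between the three compounds can be read from these numbers.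

Compound 4 `COc1ccc2nc(C)cc(OCC(=O)Nc3cc(F)cc(F)c3)c2c1` has not yet been measured. It differs from compound 3 in one place: 3,5-difluorophenyl in place of 2,5-dimethylphenyl on an amide-type nitrogen. For the measured compounds named here, with all three known values resting at the limit, no step between measured compounds can guide the expectation, and the step from compound 3 to compound 4 is expected to be a number no higher from compound 3 to compound 4 (the limit leaves the size open), nothing beyond the scatter. Compound 4 is therefore expected to give about 100000 nM in this assay, within a range from 40000 nM to 250000 nM, most likely again reported as a limit.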

Compound 4, half-maximal inhibitory concentration: > 100000 nM
Compound 4 gave a limit, no number (the forecaster's own chance of this, stated with the estimate: 85%); the middle value lies on the limit itself.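

In this assay compound 4 gives only a limit (> 100000 nM), so, with compound 3 also resting on a limit, no step between compound 3 and compound 4 can be read: the limit of > 100000 nM in this assay, at which 4 of the 4 values shown sit.

The compounds shown leave open whether any change to the shared core or its groups would give an actual number on this read-out, and how far apart such compounds would lie.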